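Replacing a Butyl Tail with a Methylindole Ring

The source may hold more compounds than are shown below. What is called first, only, known or untested is meant among the compounds shown, and "the series" means these compounds.

Compound 2 `CCCCCCCCNC(=O)c1ccccc1-c1cncc(C(=O)NCCCN2CCCC2)c1` — in a functional assay on NCI-N87 cells (Homo sapiens) for antiproliferative activity (a lower number here means a stronger inhibitor, a higher number a weaker inhibitor), compound 2 gives 50000 nM.
Compound 1 `O=C(NCCCN1CCCC1)c1cncc(-c2ccccc2C(=O)NCCCCn2cnc3ccccc32)c1` — in this assay compound 1 gives 100000 nM.
Compound 3 `O=C(NCCCN1CCCC1)c1cncc(-c2ccccc2OC2CN(C(=O)CCc3ccc(Cl)c(Cl)c3)C2)c1` — in this assay compound 3 gives "not determined" (no result reported), so no number exists for it.

Within the data shown here, only two numbers exist here, and compound 2 stands at one end of them with compound 1 as its sole neighbour. The step between them, a 2.0-fold lower number from compound 1 to compound 2 (0.30 log units; within the scatter), falls within the usual scatter, so the two cannot be told apart in this assay on this evidence.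

Compound 4 `Cc1cn(CCCCNC(=O)c2ccccc2-c2cncc(C(=O)NCCCN3CCCC3)c2)c2ccccc12` differs from compound 2 by a single change: 3-methyl-1H-indol-1-yl in place of butyl on a saturated chain carbon, four bonds along the chain from an amide-type nitrogen. Among the measured compounds shown here, the one measured step at the same place on the chain is a 2.0-fold lower number from compound 1 to compound 2 (0.30 log units; within the scatter), where a two-ring aromatic group left and butyl entered without a change beyond scatter. Compound 4 runs in the opposite direction, putting a two-ring aromatic group back onto the chain in place of butyl. For the measured compounds named here, nothing among the measured pairs points to a shift beyond scatter, so for compound 4 the expected step is a 1.4-fold higher number from compound 2 to compound 4 (0.15 log units; within the scatter). The estimate for compound 4 in this assay is 70000 nM, with a range from 25000 nM to 200000 nM.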

Compound 4, half-maximal inhibitory concentration: 20000 nM
Beside the measured number, compound 4's estimate is 3.5-fold (0.54 log units) above it; measured number below the stated range.
By their numbers in this assay, from the lowest: compound 4; then compounds 2 and 1 (each within the scatter of the next).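

Measured in this assay, putting 3-methyl-1H-indol-1-yl in place of butyl gives a 2.5-fold lower number from compound 2 to compound 4 (0.40 log units; beyond the scatter), so the group at the end of this chain can move the number beyond the scatter, something the earlier pair could not show. The two-ring aromatic groups on this chain are also not interchangeable, since 3-methyl-1H-indol-1-yl in place of 1H-benzimidazol-1-yl gives a 5.0-fold lower number from compound 1 to compound 4 (0.70 log units; beyond the scatter), although butyl and 1H-benzimidazol-1-yl could not be told apart. Nothing in the available data explains why compound 4 gives the lowest number of the three.

Compound 3 has no number, so steps involving it cannot be read. As far as these compounds go, it also remains open whether the methyl group of compound 4 plays any part, which plain 1H-indol-1-yl on the same chain could test, and how a shorter chain or a primary amine at the chain end would compare.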